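Carboxymethyl for isopropyl on the aryl hydrazone

A few compounds are considered here, and "the series" means these few. Any claim that something is new, unique, unknown or untested is made for them only; others in the source may bear on it.

Compound 3 `CC(C)c1ccc(N/N=C2\CCC(C)n3c2ncc(C(=O)O)c3=O)cc1` gives in a functional assay on the whole organism for inhibition, with Rattus norvegicus as the target (a lower number here means that less compound is needed, a higher number that more compound is needed for the effect), a reading that is a limit of the assay, > 100 umol/kg. Compound 1 `CC1CC/C(=N\Nc2ccc(O)cc2)c2ncc(C(=O)O)c(=O)n21`, which bears a hydroxy group at the same aromatic carbon, likewise gives only a limit, > 100 umol/kg. Compound 2 `COc1ccc(N/N=C2\CCC(C)n3c2ncc(C(=O)O)c3=O)cc1`, with methoxy there, gives a number, 7.6 umol/kg. Two steps frame compound 3: an at least 13-fold higher number from compound 2 to compound 3 (1.11 log units; beyond the scatter), and a step that the two limits leave unreadable from compound 1 to compound 3. Of the three values shown, two sit at the limit of > 100 umol/kg in this assay, at which 2 of the 3 values shown sit, so the position of compound 3 on the scale is known only as a limit.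

Compound 4 `CC1CC/C(=N\Nc2ccc(CC(=O)O)cc2)c2ncc(C(=O)O)c(=O)n21` differs from compound 3 in one place: carboxymethyl in place of isopropyl on an aromatic carbon. The measured steps bear on this change only loosely. The step of an at least 13-fold lower number from compound 1 to compound 2 (1.11 log units; beyond the scatter) shows that a hydrogen-bond donor at this carbon, in compound 1, left the limit unbroken, while methoxy in compound 2 gave a number. Carboxymethyl carries a donor and an acceptor, and compound 4 is therefore expected to stay near the limit rather than to follow compound 2. The step that the limit leaves unreadable from compound 3 to compound 4 is expected to be small or unreadable. Compound 4 is estimated at 150 umol/kg, within 40 umol/kg to 600 umol/kg.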

Compound 4, dose for 50% inhibition: > 100 umol/kg
Compound 4: only a limit was reported (the forecaster's own chance of this, stated with the estimate: 65%); the middle value lies beyond the limit too.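

In this assay compound 4 gives > 100 umol/kg, which is a limit of the assay and not a number. Set against methoxy, carboxymethyl at this aromatic carbon gives an at least 13-fold higher number from compound 2 to compound 4 (1.11 log units; beyond the scatter), so a third group, after hydroxy and isopropyl, fails to reach the number that methoxy gives in compound 2. The steps linking compound 4 to compound 1 and to compound 3 cannot be read, as both ends of each are limits, and among the compounds shown only methoxy at this carbon gives a number, with hydroxy, isopropyl and carboxymethyl all going against any wider trend across these groups: the limit of > 100 umol/kg in this assay, at which 3 of the 4 values shown sit.

Whether compound 1, compound 3 and compound 4 differ from one another beyond the limit stays open, as nothing shown places them on the scale. Also open, from the compounds shown here alone, is whether a close relative of methoxy, such as ethoxy, or a methyl ester in place of the carboxylic acid of the carboxymethyl chain, would give a number at this carbon as compound 2 does.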